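A few compounds are considered here, and "the series" means these few. Any claim that something is new, unique, unknown or untested is made for them only; others in the source may bear on it.

Within the data shown here, compound 3 `COc1ccc2nc(C)cc(OCC(=O)Nc3ccc(F)cc3)c2c1` is the one member of this small set that returns an actual number in a toxicity assay on HepG2 cells (Homo sapiens) for inhibition, read by CellTiter-Glo, with a stated time of 48 h (a lower number here means a stronger inhibitor, a higher number a weaker inhibitor), where compound 3 gives 63100 nM. Compound 1 `COc1ccc2nc(C)cc(OCC(=O)Nc3cc(F)cc(F)c3)c2c1` reaches only the limit of this assay, > 100000 nM. Compound 2 `COc1ccc2nc(C)cc(OCC(=O)Nc3ccc(Cl)c(OC)c3)c2c1` likewise stops at the limit, > 100000 nM, a situation described by the limit of > 100000 nM in this assay, at which 2 of the 3 values shown sit. Measured against those two limits, compound 3 shows an at least 1.5-fold lower number from compound 1 to compound 3 (0.19 log units; that floor lies within the scatter) and an at least 1.5-fold lower number from compound 2 to compound 3 (0.19 log units; that floor lies within the scatter), and the step that the two limits leave unreadable from compound 1 to compound 2 cannot be read at all. Compound 4 `COc1ccc2nc(C)cc(OCC(=O)Nc3nc(C)c(C)s3)c2c1` differs from compound 3 by 4,5-dimethyl-1,3-thiazol-2-yl in place of 4-fluorophenyl on an amide-type nitrogen. Among the measured compounds shown here, no measured step involves a 4,5-dimethyl-1,3-thiazol-2-yl group, and the steps that exist show only small, partly unreadable movement. Compound 4 is therefore expected to show a 1.1-fold higher number from compound 3 to compound 4 (0.05 log units; within the scatter), nothing beyond the scatter. Compound 4 is estimated at 70000 nM, between 20000 nM and 200000 nM.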

Compound 4, half-maximal inhibitory concentration: > 100000 nM
Compound 4: no number, only a limit; the forecaster's own chance of this, stated with the estimate: 45%; middle value at least 1.4-fold (0.15 log units) from the limit.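

Among these compounds, the change to 4,5-dimethyl-1,3-thiazol-2-yl puts a five-membered aromatic ring with 2 hetero atoms on the amide-type nitrogen for the first time, and in this assay it gives an at least 1.5-fold higher number from compound 3 to compound 4 (0.19 log units; that floor lies within the scatter). The steps from compound 1 and compound 2 to compound 4 cannot be read, as both ends are limits. Compound 3 remains the only one with a number, and a further group now ends at the limit: the limit of > 100000 nM in this assay, at which 3 of the 4 values shown sit.

As far as these compounds go, how far compound 4 lies from compound 3 stays open. So does whether a methyl group or a phenyl ring carrying a carboxylic acid on the amide-type nitrogen would return a number in this assay.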